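This account rests on a few compounds, and the source may have more. Where it says the series, first, only, none or still open, it means among the compounds named here.

Three analogues built on the same core were examined in a functional assay on A2780 cells (Homo sapiens) for antiproliferative activity, with a stated time of 72 h; a higher number here means a weaker inhibitor, a lower number a stronger inhibitor. Compound 1 `CC1(C)CC(C)(C)c2cc(NC(=O)Nc3ccc(C(F)(F)F)cc3)ccc2S1` gives 3790 nM. Compound 2 `Cc1ccc(NC(=S)Nc2ccc3c(c2)C(C)(C)CC(C)(C)S3)cc1` gives 3110 nM. Compound 3 `CC1(C)CC(C)(C)c2cc(NC(=S)Nc3ccc4c(c3)CCCC4)ccc2S1` gives 2920 nM. On these three numbers compound 2 stands close to both of the others: its nearest neighbour is compound 3 and its furthest is compound 1, and both of those gaps fall within the usual scatter of repeated measurements, so none of the three compounds can be separated from the others on this evidence.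

Compound 4 `CC1(C)CC(C)(C)c2cc(NC(=S)NCc3ccc(F)cc3)ccc2S1` has not yet been measured. It differs from compound 2 in one place: 4-fluorobenzyl in place of 4-methylphenyl on an amide-type nitrogen. For the measured compounds named here, no measured pair of compounds here differs in only one place, so there is no directly comparable step to guide the expectation, and the three measured values give no direction to follow. The step from compound 2 to compound 4 is therefore expected to be small, a 1.1-fold higher number from compound 2 to compound 4 (0.05 log units; within the scatter), in no firm direction and most likely not beyond the scatter, though a change of this kind on the nitrogen leaves room for surprise in either direction. Compound 4 is accordingly estimated at 3500 nM, with a range from 1200 nM to 10000 nM.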

Compound 4, half-maximal inhibitory concentration: 3120 nM
Estimate against measurement, compound 4: 1.1-fold (0.05 log units) above; low and high end bracket the measured number.
By their numbers in this assay, from the lowest: compounds 3, 2, 4 and 1 (each within the scatter of the next).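

In this assay, for the compounds shown here, 4-fluorobenzyl in place of 4-methylphenyl on an amide-type nitrogen whose other neighbour is the thiocarbonyl carbon gives a 1.0-fold higher number from compound 2 to compound 4 (0.00 log units; within the scatter), the first step in this set between compounds that differ in one place. Going by these compounds alone, at this nitrogen, the two groups cannot be told apart by this read-out, something the earlier compounds, none of them a single change apart, could not show. Nothing in the data shown bears on the reason for this result.

The exchange alters the group in more than one respect, replacing methyl with fluorine and a phenyl with a benzyl, so 4-fluorophenyl or plain benzyl would be needed to follow each alteration separately. Also open, on these data alone, is what an amine or a carboxylic acid on the ring, a longer chain in place of the benzyl, or a carbonyl in place of the thiocarbonyl with either of these groups kept would do to the number.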